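The compounds below may be only part of what the source reports. "The series", "measured", "known", "first", "only" and "open" are said of these compounds alone.

Measured compounds:
compound 1 `O=C1NCCN1c1ccc(S(=O)(=O)Nc2cccc(Br)c2)cc1` gives 76 nM;
compound 2 `COc1cc(NS(=O)(=O)c2ccc(N3CCNC3=O)cc2)cc(OC)c1OC` gives 170 nM;
compound 3 `COc1cccc(NS(=O)(=O)c2ccc(N3CCNC3=O)cc2)c1` gives 200 nM.

In a functional assay on CHO-TAX 5-6 cells (Cricetulus griseus) for antiproliferative activity, read by sulforhodamine B assay, with a stated time of 48 h (on this read-out lower numbers stand for stronger inhibition and higher numbers for weaker inhibition), compound 3 holds the highest of the three numbers, though its gap to compound 2 lies within the scatter; only compound 1 sits clearly lower, by a 2.6-fold higher number from compound 1 to compound 3 (0.42 log units; beyond the scatter).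

Compound 4 `COc1cc(NS(=O)(=O)c2ccc(N3CCNC3=O)cc2)cc(OC)c1` differs from compound 3 by methoxy in place of hydrogen on an aromatic carbon. For the measured compounds named here, no measured step covers this change directly. Going by the values given here, the one step on record, a 2.6-fold higher number from compound 1 to compound 3 (0.42 log units; beyond the scatter), swaps a different group and does not bear on it. The values of compound 2 and compound 3 do bear: compound 2 carries further methoxy groups on the same ring and sits within the scatter of compound 3, so compound 4 is expected to show no step beyond the scatter, a 1.1-fold lower number from compound 3 to compound 4 (0.05 log units; within the scatter). Compound 4 is therefore estimated at 180 nM, within 90 nM to 360 nM.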

Compound 4, half-maximal inhibitory concentration: 220 nM
For compound 4 the middle estimate is 1.2-fold (0.09 log units) below the measured one, within the range that was stated.
By their numbers in this assay, from the lowest: compound 1; then compounds 2, 3 and 4 (each within the scatter of the next).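

In this assay, methoxy in place of hydrogen on this aromatic carbon, meta to a large group and meta to a methoxy group, gives a 1.1-fold higher number from compound 3 to compound 4 (0.04 log units; within the scatter). Hydrogen in place of methoxy on an aromatic carbon of the same ring gives a 1.3-fold higher number from compound 2 to compound 4 (0.11 log units; within the scatter), so neither methoxy change moves the value beyond the scatter. No evidence on the origin of these small steps is available.

Open, going by these compounds, is how an amine or a carboxylic acid on this carbon would read. Also open, on these data alone, is whether bromo here would behave as it does in compound 1.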